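From 3-Fluorophenyl to 4-(Trifluoromethyl)phenyl in a Cell Tolerance Test

A few compounds are considered here, and "the series" means these few. Any claim that something is new, unique, unknown or untested is made for them only; others in the source may bear on it.

Measured in an ADME assay on MDCK cells (Canis lupus familiaris) for cytotoxicity; a lower number here means that less compound is tolerated, a higher number that more compound is tolerated:
- Compound 1 `CC(=O)Nc1ccc2oc(-c3ccnc(C(=O)N4CC5CC4CN5C(c4ccccc4)c4nnn(C)n4)c3)nc2c1`: > 50000 nM (a limit)
- Compound 2 `CC(=O)Nc1ccc2oc(-c3ccnc(C(=O)N4CC5(CCN(C(c6ccccc6)c6nnn(C)n6)CC5)C4)c3)nc2c1`: 32100 nM
- Compound 3 `CC(=O)Nc1ccc2oc(-c3ccnc(C(=O)N4CCN(C(c5cccc(F)c5)c5nnn(C)n5)CC4)c3)nc2c1`: > 50000 nM (a limit)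

Compound 3 gives > 50000 nM, which is a limit of the assay and not a number. It therefore stands at the limit of > 50000 nM in this assay, at which 2 of the 3 values shown sit. Compound 2 is the only one of the three with an actual number, 32100 nM, so a measurable reading is possible among these close relatives.

Compound 4 `CC(=O)Nc1ccc2oc(-c3ccnc(C(=O)N4CCN(C(c5ccc(C(F)(F)F)cc5)c5nnn(C)n5)CC4)c3)nc2c1` changes one group of compound 3: 4-(trifluoromethyl)phenyl in place of 3-fluorophenyl on a saturated chain carbon bound to an amine nitrogen in a ring and an aromatic carbon. In words, 4-(trifluoromethyl)phenyl takes the place of 3-fluorophenyl on a saturated chain carbon bound to an amine nitrogen in a ring and an aromatic carbon.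

Among the measured compounds shown here, no pair of measured compounds isolates a change of this kind, so the expectation rests on little. A small drop in this assay is expected, possibly none beyond the scatter, and another limit would be no surprise. The expected change is an at least 1.2-fold lower number from compound 3 to compound 4 (0.09 log units; that floor lies within the scatter). Compound 4 is estimated at 40000 nM, with an expected range from 18000 nM to 50000 nM.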

Compound 4, half-maximal cytotoxic concentration: > 50000 nM
Compound 4: no number, only a limit; the forecaster's own chance of this, stated with the estimate: 55%; middle value at least 1.2-fold (0.09 log units) away from the limit.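

In this assay compound 4 gives > 50000 nM as a limit of the assay and not a number. Compound 3 also stands at a limit, so no step from compound 3 to compound 4 can be read, because both rest on the same limit: the limit of > 50000 nM in this assay, at which 3 of the 4 values shown sit.

On these data alone, whether 4-(trifluoromethyl)phenyl in place of 3-fluorophenyl changes cell tolerance at all stays open.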